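This account rests on a few compounds, and the source may have more. Where it says the series, first, only, none or still open, it means among the compounds named here.

Three amide-bearing compounds that share one core have been compared in a functional assay on MCF7 cells (Homo sapiens) for antiproliferative activity, read by MTT assay, with a stated time of 72 h; a lower number here means a stronger inhibitor, a higher number a weaker inhibitor. Compound 1 `CCN(CC)CCNc1cc(C)c2cc(NC(=O)c3ccc(Cl)c(Cl)c3)ccc2n1` gives 1420 nM in this assay. Compound 2 `Cc1cc(NCCN2CCN(C)CC2)nc2ccc(NC(=O)c3ccc(Cl)c(Cl)c3)cc12` gives 1700 nM in this assay, and compound 3 `CCN1CCN(c2cc(C)c3cc(NC(=O)c4ccc(Cl)c(Cl)c4)ccc3n2)CC1` gives 1380 nM in this assay. The three numbers sit close together: the step of a 1.2-fold higher number from compound 1 to compound 2 (0.08 log units; within the scatter), the step of a 1.0-fold lower number from compound 1 to compound 3 (0.01 log units; within the scatter) and the step of a 1.2-fold lower number from compound 2 to compound 3 (0.09 log units; within the scatter) are each within the scatter, so compound 3 stands at the lowest of the three numbers without being separated from either neighbour.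

Compound 4 `Cc1cc(N2CCN(C)CC2)nc2ccc(NC(=O)c3ccc(Cl)c(Cl)c3)cc12` differs from compound 3 by hydrogen in place of methyl on a saturated chain carbon bound to an amine nitrogen in a ring. Among the compounds with values here, no measured pair isolates this change on its own. The nearest evidence is the step from compound 2 to compound 3, which swaps a 4-methylpiperazin-1-yl bearing group for a 4-ethylpiperazin-1-yl while also removing the chain, and stays within the scatter; the steps from compound 1 to compound 2 and from compound 1 to compound 3 likewise show that reshaping this basic side group leaves the number essentially unchanged. He therefore expects the step of a 1.1-fold higher number from compound 3 to compound 4 (0.02 log units; within the scatter) to be no larger than the scatter, in no firm direction. For compound 4 he estimates 1450 nM in this assay, with a range from 700 nM to 3000 nM.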

Compound 4, half-maximal inhibitory concentration: 3000 nM
Compound 4: middle estimate off by 2.1-fold (0.32 log units), on the low side, and the stated range covers the measured number.
By their numbers in this assay, from the lowest: compounds 3, 1, 2 and 4 (each within the scatter of the next, the first and the last beyond it).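

Within the data shown here, the change from 4-ethylpiperazin-1-yl to 4-methylpiperazin-1-yl gives a 2.2-fold higher number from compound 3 to compound 4 (0.34 log units; beyond the scatter) in this assay and is the first single change at this side group to pass the scatter, so losing one methyl on a saturated chain carbon bound to an amine nitrogen in a ring registers where the earlier reshaping of the side group did not. The comparisons with the chain-bearing compounds divide, since a 2.1-fold higher number from compound 1 to compound 4 (0.32 log units; beyond the scatter) also lies beyond the scatter while a 1.8-fold higher number from compound 2 to compound 4 (0.25 log units; within the scatter) stays within it, which separates compound 4 from compound 3 and compound 1 but not from compound 2. No evidence at hand bears on why the ethyl-to-methyl step reads as it does.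

With only ethyl and methyl shown on this piperazine nitrogen, the compounds leave open how a propyl group, a 2-hydroxyethyl group or a bare hydrogen there would read. They also leave open whether the ethyl-to-methyl change reads the same way in a compound that keeps the ethylamino chain, since here it rests on one pair.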